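Trimethoxyphenyl pyrazole chalcones against colon carcinoma cells

A few compounds are considered here, and "the series" means these few. Any claim that something is new, unique, unknown or untested is made for them only; others in the source may bear on it.

The series rests on a pyrazolyl enone core, read in a functional assay on SW-620 cells (Homo sapiens) for cytotoxicity, read by sulforhodamine B assay, with a stated time of 48 h, tested at 0.1 uM; a lower number here means a stronger effect, a higher number a weaker effect of the compound at the concentration tested. Compound 1 `COc1cc(-c2cc(/C=C/C(=O)c3ccc(Cl)c(Cl)c3)[nH]n2)cc(OC)c1OC` carries a 3,4-dichlorophenyl group on its carbonyl carbon; in this assay compound 1 gives 99%. Its companion compound 2 `COc1ccc(-c2cc(/C=C/C(=O)c3ccc(N)cc3)[nH]n2)cc1OC` bears an aminophenyl group in the same region, and in this assay compound 2 gives 97%. The two numbers lie within the usual scatter of each other, so neither compound can be called stronger or weaker than the other at the concentration tested, and both sit close to no effect at all.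

Compound 3 `COc1ccc(C(=O)/C=C/c2cc(-c3cc(OC)c(OC)c(OC)c3)n[nH]2)cc1OC` differs from compound 1 in a single place: 3,4-dimethoxyphenyl in place of 3,4-dichlorophenyl on a carbonyl carbon. Among the measured compounds shown here, no pair of measured compounds shows a step that isolates this kind of exchange, so the expectation rests on what the two values show. Since compound 1 gives 99% and compound 2 gives 97%, both within the scatter of each other, the step of a number 2 percentage points lower from compound 1 to compound 3 (within the scatter) is expected to stay within the scatter in either direction. Compound 3 is therefore estimated at 97%, with a range from 85% to 105%.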

Compound 3, a percentage reported as activity, at one concentration (the size of the read-out at that concentration, not a potency): 99%
Compound 3: the middle estimate sits 2 percentage points below what was measured, and the stated range covers the measured number.
By their numbers in this assay, from the lowest: compounds 2, 1 and 3 (each within the scatter of the next).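

Among the compounds shown here, the exchange of 3,4-dichlorophenyl for 3,4-dimethoxyphenyl on a carbonyl carbon gives the only readable step, and in this assay it shows no change at the digits printed from compound 1 to compound 3 (within the scatter). This is direct evidence that was missing while only compound 1 and compound 2, which differ in more than one place, were at hand: at this position, a group with hydrogen-bond acceptors can enter in place of one without them and the read-out stays within the scatter. However, compound 1 and compound 3 both sit close to no effect at the one concentration tested, so the step cannot show whether the two groups would differ where the compounds have a clear effect, and no measurement offers any explanation for the result.

The compounds shown leave open whether any group on this carbonyl carbon can move the read-out away from no effect. A carboxylic acid or a piperazine there would test this, as would a longer chain in place of the methoxy groups of compound 3.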